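The compounds below may be only part of what the source reports. "The series", "measured", "known", "first", "only" and "open" are said of these compounds alone.

Compound 1 `CN(C)C(=S)N/N=C/c1ccc2ccccc2n1`: 30 nM
Compound 2 `NC(=S)N/N=C/c1cc2ccccc2s1`: > 100000 nM, a limit of the assay rather than a number.

For the measured compounds named here, in a functional assay on SGC-7901 cells (Homo sapiens) for antiproliferative activity, read by sulforhodamine B assay, with a stated time of 72 h (on this read-out lower numbers stand for stronger inhibition and higher numbers for weaker inhibition), compound 1 stands as the only value given as a number; the other result is a limit (the limit of > 100000 nM in this assay, at which 1 of the 2 values shown sits). Compound 3 `S=C(N/N=C/c1ccc2ccccc2n1)Nc1ccccc1` is not yet measured in this assay and differs from compound 1 in one place: anilino in place of dimethylamino on a thiocarbonyl carbon. Going by the values given here, no measured pair covers this exchange, so the step is estimated without a direct precedent. The change from compound 1 to compound 3 is expected to give a 10-fold higher number from compound 1 to compound 3 (1.00 log units; beyond the scatter), a step toward weaker inhibition that lies beyond the usual scatter. Compound 3 is estimated at 300 nM, within a range from 50 nM to 3000 nM.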

Compound 3, half-maximal inhibitory concentration: 26500 nM
For compound 3 the middle estimate is 88-fold (1.95 log units) below the measured one; measured number outside the range, above it.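

The group on the thiocarbonyl carbon decides much of the activity of this series: in this assay anilino in place of dimethylamino gives an 880-fold higher number from compound 1 to compound 3 (2.95 log units; beyond the scatter) and shows that the shared core alone does not hold the activity at the level of compound 1. Nothing shown gives a cause for this loss. Still open, from the compounds shown here alone, is whether the ring of anilino or its hydrogen-bond donor goes with the loss; piperidine or methylamino on the same carbon would separate the two.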